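A Carbonyl Swap on Compound 1

A few compounds are considered here, and "the series" means these few. Any claim that something is new, unique, unknown or untested is made for them only; others in the source may bear on it.

Going by the values given here, in a functional assay on MDA-MB-231 cells (Homo sapiens) for antiproliferative activity, read by MTT assay, with a stated time of 24 h (a lower number here means a stronger inhibitor, a higher number a weaker inhibitor), compound 1 `O=C(NNc1cccc(Cl)c1)c1cccc(NS(=O)(=O)c2cnc(O)nc2O)c1` gives 7760 nM as the only exact number so far. Compound 2 `Cc1cccc(NNC(=O)c2ccccc2NS(=O)(=O)c2cnc(O)nc2O)c1` gives > 20000 nM as a limit of the assay, not a number. Compound 3 `O=C(NNC(=O)c1ccc(NS(=O)(=O)c2cnc(O)nc2O)cc1)c1ccc(F)cc1` carries a fluorophenyl carbonyl on such a nitrogen and gives > 20000 nM as another limit, which suggests that compound 4 will be a weaker inhibitor than compound 1. The change (2-fluorophenyl)carbonyl in place of 3-chlorophenyl on an amine nitrogen puts (2-fluorophenyl)carbonyl in place of 3-chlorophenyl on an amine nitrogen of compound 1 to give compound 4 `O=C(NNC(=O)c1ccccc1F)c1cccc(NS(=O)(=O)c2cnc(O)nc2O)c1` with the core unchanged. The expected step of a 2.3-fold higher number from compound 1 to compound 4 (0.37 log units; beyond the scatter) is modest in size and points toward weaker inhibition. In this assay the estimated value for compound 4 is 18000 nM within an expected range from 8000 nM to 40000 nM at the top.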

Compound 4, half-maximal inhibitory concentration: > 20000 nM
Compound 4 gave a limit, no number; the forecaster's own chance of this, stated with the estimate: 60%; middle value at least 1.1-fold (0.04 log units) away from the limit.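

Compound 4 gives > 20000 nM in this assay, which is a limit and not a number. Going by these compounds alone, it still supplies the first one-place comparison at this amine nitrogen, where (2-fluorophenyl)carbonyl in place of 3-chlorophenyl gives an at least 2.5-fold higher number from compound 1 to compound 4 (0.41 log units; beyond the scatter). The full size of this step cannot be read because the value stops at the assay limit: the limit of > 20000 nM in this assay, at which 3 of the 4 values shown sit.

From the compounds shown here alone, both a carbonyl and a different halogen enter in this one change, so it remains open which of them matters. A benzoyl group or a plain alkyl chain on this nitrogen would help separate them.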